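Replacing a fluorophenyl with a methoxyphenyl: cell tolerance

The compounds below may be only part of what the source reports. "The series", "measured", "known", "first", "only" and "open" are said of these compounds alone.

Compound 1 has the structure `COc1nc(-c2ccccc2F)ccc1[C@@H](c1ccccc1)[C@@](O)(CCN(C)C)c1cccc2ccccc12`. In a toxicity assay on Vero cells (Chlorocebus sabaeus) for cytotoxicity (a higher number here means that more compound is tolerated, a lower number that less compound is tolerated), compound 1 gives > 50 ug/mL, which is a limit of the assay rather than a measured number. Two close relatives have been tested in this assay. Compound 2, `COc1nc(-c2ccc(Br)cc2)ccc1[C@@H](c1ccccc1)[C@@](O)(CCN(C)C)c1cccc2ccccc12`, gives > 50 ug/mL, again a limit. Compound 3, `COc1ncc(-c2ccccc2)cc1[C@@H](c1ccccc1)[C@@](O)(CCN(C)C)c1ccccc1`, gives > 50 ug/mL, also a limit. Among the measured compounds shown here, the one step between measured compounds that differ in a single place, a step that the two limits leave unreadable from compound 1 to compound 2, therefore cannot be sized. What the three results do share is the limit of > 50 ug/mL in this assay, at which 3 of the 3 values shown sit.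

Compound 4, `COc1ccc(-c2ccc([C@@H](c3ccccc3)[C@@](O)(CCN(C)C)c3cccc4ccccc34)c(OC)n2)cc1`, has not yet been tested in this assay. It differs from compound 1 by 4-methoxyphenyl in place of 2-fluorophenyl on an aromatic carbon. For the measured compounds named here, no measured step bears readably on this change, since each of the three tested compounds sits at the limit. Given that, compound 4 is expected to sit at or near the same limit, so the estimated step that the limit leaves unreadable from compound 1 to compound 4 is expected to be none beyond the scatter. For compound 4 the estimate in this assay is 60 ug/mL, with a range from 30 ug/mL to 120 ug/mL.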

Compound 4, half-maximal cytotoxic concentration: > 50 ug/mL
Compound 4: a limit, no number (the forecaster's own chance of this, stated with the estimate: 80%); the middle value does not contradict the limit.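

In this assay compound 4 gives > 50 ug/mL, which is a limit and not a number. Its steps from compound 1 and compound 2 therefore cannot be read. The compounds shown leave open how much of each compound the cells actually tolerate, and whether exchanging these groups changes that.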